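A few compounds are considered here, and "the series" means these few. Any claim that something is new, unique, unknown or untested is made for them only; others in the source may bear on it.

The study concerns cytotoxicity in an ADME assay on RAW264.7 cells (Mus musculus) for cytotoxicity, read by MTT assay, with a stated time of 24 h, in the presence of a further agent that is not named here; a lower number here means a stronger inhibitor, a higher number a weaker inhibitor. Compound 1 `O=C1OC(Cc2nc(-c3ccc(Oc4ccccc4)cc3)no2)c2ccccc21` gives only a limit in this assay and no number, namely > 40000 nM. Compound 2 `COCCCOc1ccc(C(O)C2OC(=O)c3c(OC)cc(OC)cc32)cc1` likewise returns only a limit in this assay, > 40000 nM. Compound 2 therefore stands at the boundary of the measurement rather than at a value, because the limit of > 40000 nM in this assay, at which 2 of the 2 values shown sit, marks the point where both results shown sit. Within the data shown here, no step between measured compounds is available. Compound 3 `COc1cc(OC)c2c(c1)C(C(O)c1ccc(OCc3ccc(OC(F)F)cc3)cc1)OC2=O` remains to be measured in this assay. It differs from compound 2 in one place: 4-(difluoromethoxy)phenyl in place of 2-methoxyethyl on a saturated chain carbon bound to an oxygen on an aromatic ring. Among the measured compounds shown here, with no measured step to guide the size of the change, the expected step of a number no higher from compound 2 to compound 3 (the limit leaves the size open) is put at none beyond the scatter. The expected outcome for compound 3 in this assay is 40000 nM, within a range from 15000 nM to 100000 nM, with a further limit the likeliest report.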

Compound 3, half-maximal inhibitory concentration: > 40000 nM
Compound 3 was reported as a limit (the forecaster's own chance of this, stated with the estimate: 70%); the middle value lies on the limit itself.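

Compound 2 and compound 3 each give only a limit in this assay, so no step can be read between them: the limit of > 40000 nM in this assay, at which 3 of the 3 values shown sit.

The compounds shown leave open whether 4-(difluoromethoxy)phenyl in place of 2-methoxyethyl changes the half-maximal inhibitory concentration in this assay at all.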